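The source may hold more compounds than are shown below. What is called first, only, known or untested is meant among the compounds shown, and "the series" means these compounds.

The measured compounds:

Compound 1, `CCCS(=O)(=O)Nc1ccc(F)c(C(=O)c2n[nH]c3ncc(-c4ccccc4F)cc23)c1F`: 2%
Compound 2, `CCCS(=O)(=O)Nc1ccc(F)c(C(=O)c2n[nH]c3ncc(-c4ccc(OC)cc4Cl)cc23)c1F`: 5.3%
Compound 3, `CCCS(=O)(=O)Nc1ccc(F)c(C(=O)c2n[nH]c3ncc(-c4ccc(-c5nnn[nH]5)cc4)cc23)c1F`: 0.15%

All three were tested in an assay for binding affinity to dual specificity mitogen-activated protein kinase kinase 4 (Homo sapiens), read by KINOMEscan, tested at 100 nM; on this read-out lower numbers stand for a stronger effect and higher numbers for a weaker effect at the one concentration tested. Compound 3 gives the lowest of the three numbers, but its gap to the others is small: a number 1.9 percentage points lower from compound 1 to compound 3 (within the scatter), and a number 5.2 percentage points lower from compound 2 to compound 3 (within the scatter). Neither gap is large enough to place compound 3 apart from compound 1 or compound 2, so the three stand together on this read-out.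

The unmeasured compound 4, `CCCS(=O)(=O)Nc1ccc(F)c(C(=O)c2n[nH]c3ncc(-c4ccc(S(N)(=O)=O)cc4C)cc23)c1F`, shares the core of compound 3 and differs from it in one place: 2-methyl-4-sulfamoylphenyl in place of 4-(1H-tetrazol-5-yl)phenyl on an aromatic carbon.

Every measured step bears on this change, since each of them swaps the aryl group at this same position of the core. a number 3.3 percentage points higher from compound 1 to compound 2 (within the scatter), a number 1.9 percentage points lower from compound 1 to compound 3 (within the scatter) and a number 5.2 percentage points lower from compound 2 to compound 3 (within the scatter) all fall within the scatter, whether the group carries a halogen, a methoxy group or a tetrazole ring. From compound 3 to compound 4 the step is therefore expected to be none beyond the scatter, estimated as a number 1.9 percentage points higher from compound 3 to compound 4 (within the scatter). Compound 4 is expected to give about 2% in this assay, estimated to lie between 0.1% and 12%.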

Compound 4, a percentage reported as activity, at one concentration (the size of the read-out at that concentration, not a potency): 3.1%
For compound 4 the middle estimate is 1.1 percentage points below the measured one; low and high end bracket the measured number.
By their numbers in this assay, from the lowest: compounds 3, 1, 4 and 2 (each within the scatter of the next).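

In this assay the step to the new group stays small from every side: a number 3 percentage points higher from compound 3 to compound 4 (within the scatter) and a number 2.2 percentage points lower from compound 2 to compound 4 (within the scatter) and a number 1.1 percentage points higher from compound 1 to compound 4 (within the scatter) leave compound 4 among the other three. The earlier compounds had shown this only for aryl groups carrying a halogen, a methoxy group or a tetrazole ring, whereas 2-methyl-4-sulfamoylphenyl brings a sulfamoyl group with its 2 double bonds outside aromatic rings and keeps a single six-membered aromatic ring of carbon only. Replacing the five-membered aromatic ring of compound 3 in this way therefore moves the number no further than the scatter, and nothing available here accounts for this tolerance.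

The methyl and sulfamoyl groups enter together, so the share of each stays unseparated, and all four compounds were read at one concentration, which leaves open whether they differ in potency. Also open, going by these compounds, is whether a carboxylic acid or an aminomethyl group on the phenyl ring, or a morpholine in place of that ring, would stay within the scatter at this position.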